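The source may hold more compounds than are shown below. What is called first, only, known or untested is meant among the compounds shown, and "the series" means these compounds.

Measured compounds:
compound 1, `CN1CCC(c2ccc3c(c2)oc(=O)n3C(=O)NCCCCc2ccccc2)CC1=O`, 105 nM
compound 2, `CC(C)CNC(=O)n1c(=O)oc2cc(C3CCCCN3C)ccc21`, 1010 nM

The account follows one change made to compound 1. Of the two compounds measured in an assay on HEK293 cells for inhibition of acid ceramidase (Homo sapiens), read by fluorescence, with stated times of 10 min and 3 h (a higher number here means a weaker inhibitor, a lower number a stronger inhibitor), compound 1 has the lowest number: compound 2 gives a higher value, and the gap between the two lies beyond the usual scatter of the measurement, so compound 1 is the stronger inhibitor of this pair. For the measured compounds named here, the two compounds differ in more than one place, and no single step between them has been worked out, so nothing more than the two values themselves can be read from that comparison.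

Compound 3, `CCN1CCC(c2ccc3c(c2)oc(=O)n3C(=O)NCCCCc2ccccc2)CC1`, has not yet been measured in this assay. It differs from compound 1 in one place: 1-ethylpiperidin-4-yl in place of 1-methyl-2-oxopiperidin-4-yl on an aromatic carbon. The shared core and the chain on the other side of it are untouched. Going by the values given here, no measured pair isolates this kind of change, so the size of the step is uncertain; compound 3 is expected to land near compound 1, with a step in this assay of a 1.5-fold higher number from compound 1 to compound 3 (0.18 log units; within the scatter), which is within the scatter or slightly toward a weaker inhibitor. For compound 3 the estimate in this assay is 160 nM, with a range from 40 nM to 650 nM.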

Compound 3, half-maximal inhibitory concentration: 92 nM
The estimate for compound 3 lay 1.7-fold (0.24 log units) above the measured number, and the stated range covers the measured number.
By their numbers in this assay, from the lowest: compounds 3 and 1 (each within the scatter of the next); then compound 2.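

In this assay, placing 1-ethylpiperidin-4-yl where compound 1 carries 1-methyl-2-oxopiperidin-4-yl gives a 1.1-fold lower number from compound 1 to compound 3 (0.06 log units; within the scatter), so the two compounds cannot be told apart on this read-out. For the compounds shown here, this is the first comparison in which only this position on the aromatic carbon differs, and it shows that this change, which removes the ring carbonyl and replaces the methyl on the ring nitrogen with an ethyl, leaves no effect on the number that can be distinguished from the scatter of the measurement. No further data accompany this result that could account for the match between the two compounds.

The carbonyl and the ethyl change together in this step, so the compounds shown cannot say whether each alone would leave the number as it stands or whether two separate effects offset each other, a question that 1-methylpiperidin-4-yl at the same place would help to settle. Also open, as far as these compounds go, is how a larger or quite different group on this aromatic carbon, such as 1-benzylpiperidin-4-yl or a carboxylic acid, would read in this assay.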